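The compounds below may be only part of what the source reports. "The series", "measured", "known", "first", "only" and "open" are said of these compounds alone.

Measured compounds:
compound 1 `CC(=O)NC1CCN(S(=O)(=O)c2ccc(F)cc2)CC1` — 0.01 mg/kg
compound 2 `CCC(=O)N1CCCC(NS(=O)(=O)c2ccc(F)cc2)C1` — 10 mg/kg
compound 3 `CC(C)S(=O)(=O)NC1CCCN(C(=O)c2ccccc2)C1` — 1 mg/kg

In a functional assay on the whole organism with Mus musculus as the target, with a stated time of 30 min (a higher number here means that more compound is needed for the effect, a lower number that less compound is needed), compound 1 gives 0.01 mg/kg, compound 3 gives 1 mg/kg, and compound 2 gives 10 mg/kg. Compound 2 thus stands at the highest number of the three: its nearest neighbour is compound 3, whose number is lower by a gap beyond the scatter, and compound 1 lies further still, also beyond the scatter. The account now turns to compound 4 `CC(C)S(=O)(=O)N1CCCC(NS(=O)(=O)c2ccc(F)cc2)C1`, which has not yet been measured in this assay.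

Compound 4 differs from compound 2 in a single place: isopropylsulfonyl in place of propanoyl on an amine nitrogen in a ring

Within the data shown here, no measured pair shows this same exchange, so its effect in this assay cannot be read from a parallel step. Compound 3 carries an isopropylsulfonyl group and gives 1 mg/kg, a lower number than compound 2, but it also differs from compound 2 elsewhere, so this is only a loose hint. Compound 4 is therefore expected to move toward a somewhat lower number than compound 2, a step of a 3.3-fold lower number from compound 2 to compound 4 (0.52 log units; beyond the scatter), though a result within the scatter would not surprise. The estimate for compound 4 in this assay is 3 mg/kg, with a range from 0.3 mg/kg to 30 mg/kg.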

Compound 4, minimum effective dose: 10 mg/kg
Beside the measured number, compound 4's estimate is 3.3-fold (0.52 log units) below it, within the range that was stated.
By their numbers in this assay, from the lowest: compound 1; then compound 3; then compounds 2 and 4 (each within the scatter of the next).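

In this assay, isopropylsulfonyl in place of propanoyl on an amine nitrogen in a ring gives no change at the digits printed from compound 2 to compound 4 (within the scatter). Among these compounds, this is the first change that can be read on its own, since the earlier compounds offered no pair differing in one place, and it shows that on this nitrogen of the shared core, the two groups cannot be told apart in this read-out. No available evidence explains why they read alike.

As far as these compounds go, this reading rests on a single pair, so it remains open whether the same exchange would also leave the number unchanged in the core of compound 1. From the compounds shown here alone, it is also open whether a group of another kind on this nitrogen, such as a simple amine, a carboxylic acid or a longer acyl chain, would shift the number from that of compound 2.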